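This account rests on a few compounds, and the source may have more. Where it says the series, first, only, none or still open, it means among the compounds named here.

The compounds measured so far:

Compound 1, `NC1=NC2(CCOCC2)N(OCCCOc2ccc(Cl)cc2)C(N)=N1`, gives > 90% in an assay on isolated protein for inhibition of Dihydrofolate reductase (Homo sapiens), read by spectrophotometry, using NADPH, with stated times of 5 s and 6 min, tested at 5 uM (a lower number here means a weaker effect, a higher number a stronger effect of the compound at the concentration tested), and this is a limit of the assay rather than a number.

Compound 2, `NC1=NC2(CCOCC2)N(OCCCOc2ccc(Br)cc2)C(N)=N1`, gives > 90% in this assay, again a limit of the assay and not a number.

Within the data shown here, compound 2 therefore stands at the limit of > 90% in this assay, at which 2 of the 2 values shown sit, the same limit at which compound 1 sits, so the step that the two limits leave unreadable from compound 1 to compound 2 cannot be read in size; it says only that the change from chloro to bromo did not pull the value below that limit.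

Compound 3, `CC(C)(C)c1ccc(OCCCON2C(N)=NC(N)=NC23CCOCC3)cc1`, has not yet been measured in this assay. It differs from compound 2 by tert-butyl in place of bromo on an aromatic carbon. Among the measured compounds shown here, no measured step bears directly on this change; what the data show is that both measured compounds, with either halogen in that place, sit at the limit. Compound 3 is therefore expected to show a step that the limit leaves unreadable from compound 2 to compound 3 that stays within the scatter. The estimate for compound 3 in this assay is 91%, with a range from 75% to 98%.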

Compound 3, a percentage reported as inhibition, at one concentration (the size of the read-out at that concentration, not a potency): > 90%
Compound 3: only a limit was reported; the forecaster's own chance of this, stated with the estimate: 65%; the middle value does not contradict the limit.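

In this assay compound 3 gives > 90% as a limit of the assay and not a number. The steps to compound 3 from compound 1 and compound 2 therefore cannot be read in size: the limit of > 90% in this assay, at which 3 of the 3 values shown sit. Going by these compounds, what stays open is whether chloro, bromo and tert-butyl on that aromatic carbon truly differ, and which change there would bring a value off the limit.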